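The compounds below may be only part of what the source reports. "The series", "measured", "known", "first", "only" and "open" are said of these compounds alone.

Compound 1, `NC(=O)c1c(NC(=O)c2ccccc2Cl)sc2c1CCN(C(=S)Nc1ccccc1Br)C2`, gives 24600 nM in a functional assay on HeLa cells (Homo sapiens) for antiproliferative activity, with a stated time of 24 h; a higher number here means a weaker inhibitor, a lower number a stronger inhibitor.
Compound 2, `Cc1ccccc1NC(=S)N1CCc2c(sc(NC(=O)c3ccccc3Cl)c2C(N)=O)C1`, gives > 50000 nM in this assay, which is a limit of the assay rather than a number.
Compound 3, `NC(=O)c1c(NC(=O)c2ccccc2Cl)sc2c1CCN(C(=S)Nc1ccccc1-c1ccccc1)C2`, gives 24000 nM in this assay.

Compound 3 and compound 1 sit within the scatter of each other, as a 1.0-fold lower number from compound 1 to compound 3 (0.01 log units; within the scatter) shows. The step of an at least 2.0-fold lower number from compound 2 to compound 3 (0.31 log units; beyond the scatter) is beyond the scatter; the value of compound 2 is the limit of > 50000 nM in this assay, at which 1 of the 3 values shown sits. Compound 4, `NC(=O)c1c(NC(=O)c2ccccc2Cl)sc2c1CCN(C(=S)Nc1ccc(C(F)(F)F)cc1)C2`, is not yet measured and differs from compound 3 by 4-(trifluoromethyl)phenyl in place of 2-phenylphenyl on an amide-type nitrogen. The steps at this aryl group bear on it: a 1.0-fold lower number from compound 1 to compound 3 (0.01 log units; within the scatter), an at least 2.0-fold higher number from compound 1 to compound 2 (0.30 log units; that floor lies within the scatter) and an at least 2.0-fold lower number from compound 2 to compound 3 (0.31 log units; beyond the scatter), all small. For compound 4 a step of a 1.3-fold higher number from compound 3 to compound 4 (0.10 log units; within the scatter) is therefore expected, within the scatter. Compound 4 is estimated at 30000 nM, between 15000 nM and 60000 nM.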

Compound 4, half-maximal inhibitory concentration: > 50000 nM
Compound 4: no number, only a limit (the forecaster's own chance of this, stated with the estimate: 30%); middle value at least 1.6-fold (0.22 log units) from the limit.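

At this aryl group on the amide-type nitrogen, 4-(trifluoromethyl)phenyl gives an at least 2.0-fold higher number from compound 3 to compound 4 (0.31 log units; beyond the scatter) and an at least 2.0-fold higher number from compound 1 to compound 4 (0.30 log units; that floor lies within the scatter), so the position does not accept every aryl group equally in this assay. Compound 4 gives a limit rather than a number, the same limit as compound 2: the limit of > 50000 nM in this assay, at which 2 of the 4 values shown sit. The step between these two compounds cannot be read. On these data alone, how far the true values of compound 2 and compound 4 lie beyond the limit stays open. Also open, as far as these compounds go, is whether an amine or a carboxylic acid on this aryl ring would give a readable number.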